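The source may hold more compounds than are shown below. What is called first, only, known or untested is meant among the compounds shown, and "the series" means these compounds.

Compound 1 `CCCc1nc(C)c2c(-c3ccccc3)nnc(O)n12`, compound 2 `CCCc1nc(C)c2c(C(C)C)cnc(Nc3cc[nH]n3)n12` and compound 3 `CCCc1nc(C)c2c(CC)cnc(Nc3cc[nH]n3)n12` were tested in a functional assay for inhibition, with Homo sapiens as the target; a higher number here means a weaker inhibitor, a lower number a stronger inhibitor. In this assay compound 1 gives only a limit, > 48000 nM. Compound 2 likewise reaches only a limit, > 48000 nM. Compound 3 also gives only a limit, > 48000 nM. The difference between the core of compound 1 and that of compound 2 is not broken down here. Compound 3 differs from compound 2 by hydrogen in place of methyl on a saturated chain carbon bound to an aromatic carbon and a saturated chain carbon, and the step that the two limits leave unreadable from compound 2 to compound 3 cannot be sized since (the limit of > 48000 nM in this assay, at which 3 of the 3 values shown sit). Compound 4 `CCc1nc(C)c2c(-c3ccccc3)nnc(O)n12`, not yet measured, differs from compound 1 by the same kind of change, (hydrogen in place of methyl on a saturated chain carbon, two bonds along the chain from an aromatic carbon); here the carbon sits two bonds along the chain from an aromatic carbon rather than bound to an aromatic carbon and a saturated chain carbon. Because compound 1 gives only the limit > 48000 nM, a limit is expected for compound 4 as well. The step that the limit leaves unreadable from compound 1 to compound 4 is expected to be small. In this assay compound 4 is estimated at 60000 nM.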

Compound 4, half-maximal inhibitory concentration: > 48000 nM
Compound 4 ended at the assay's limit; the forecaster's own chance of this, stated with the estimate: 85%; the middle value is on the limit's open side.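

The step from compound 1 to compound 4 cannot be read, as both values are limits and not numbers: the limit of > 48000 nM in this assay, at which 4 of the 4 values shown sit. The compounds shown leave open how strongly any of them inhibits, and whether going from propyl to ethyl changes that at all.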